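The compounds below may be only part of what the source reports. "The series", "measured", "known", "first", "only" and "open" are said of these compounds alone.

Compound 3, whose structure is `CC(C)(C)c1ccc(O)c(/C=N/NC(=O)c2cccs2)c1`, stands highest of the two plain numbers in a functional assay on MRC5 cells (Homo sapiens) for cytotoxicity, read by colorimetric assay and MTT assay (a higher number here means that more compound is tolerated, a lower number that less compound is tolerated), where compound 3 gives 12000 nM. Compound 1, `CC(C)(C)c1ccc(O)c(/C=N/NC(=O)c2ccccc2)c1`, gives in this assay 2600 nM. Compound 2, `COc1ccc(C(=O)N/N=C/c2cc(C(C)(C)C)ccc2O)cc1`, reaches only a limit of this assay, > 100000 nM, so for compound 2 no number is known (the limit of > 100000 nM in this assay, at which 1 of the 3 values shown sits).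

Compound 4 has the structure `CC(C)(C)c1ccc(O)c(/C=N/NC(=O)c2ccc(Cl)cc2)c1`. It differs from compound 3 in one place: 4-chlorophenyl in place of thiophen-2-yl on a carbonyl carbon.

Going by the values given here, two measured steps touch the same carbonyl carbon. The step of a 4.6-fold higher number from compound 1 to compound 3 (0.66 log units; beyond the scatter) shows that exchanging phenyl for thiophen-2-yl raised the number, so the reverse direction, back to a six-membered carbon ring, argues for a lower number. The step of an at least 8.3-fold lower number from compound 2 to compound 3 (0.92 log units; beyond the scatter), in which thiophen-2-yl replaced 4-methoxyphenyl, lowered the number, which argues the other way for a phenyl carrying a group in the same position. The step of an at least 38-fold higher number from compound 1 to compound 2 (1.58 log units; beyond the scatter) shows how far a single group on that ring can move the number. Whether chlorine behaves like methoxy here is not shown by any compound.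

Weighing these, compound 4 is expected to land near 15000 nM, within a wide range from 3000 nM to 80000 nM, which would mean an estimated step of a 1.3-fold higher number from compound 3 to compound 4 (0.10 log units; within the scatter).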

Compound 4, half-maximal cytotoxic concentration: 3600 nM
For compound 4 the middle estimate is 4.2-fold (0.62 log units) above the measured one; the range from low to high includes it.
By their numbers in this assay, from the lowest: compounds 1 and 4 (each within the scatter of the next); then compound 3. At a limit, above all of these: compound 2.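

In this assay, chloro in place of hydrogen on the aromatic carbon gives a step that stays within the scatter (a 1.4-fold higher number from compound 1 to compound 4 (0.14 log units; within the scatter)), so the large step seen with methoxy is not a general outcome of placing any group there. The exchange of one group for the other carries a large step of its own (an at least 27-fold lower number from compound 2 to compound 4 (1.44 log units; beyond the scatter)), which shows that chloro and methoxy are not interchangeable at this position. The change from the five-membered ring is also beyond the scatter (a 3.3-fold lower number from compound 3 to compound 4 (0.52 log units; beyond the scatter)), so thiophen-2-yl stands above both phenyl and 4-chlorophenyl, a pattern that holds among compound 1, compound 3 and compound 4, while compound 2, with its 4-methoxyphenyl, goes against it.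

Compound 2 stands only at a limit, not at a number: the limit of > 100000 nM in this assay, at which 1 of the 4 values shown sits. On these data alone, how far methoxy really moves the number therefore stays open, as does whether an amine, a carboxylic acid or a longer chain in the place of chloro would follow methoxy or chloro.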